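This account rests on a few compounds, and the source may have more. Where it says the series, first, only, none or still open, it means among the compounds named here.

Measured so far in an in vitro functional assay on Sf9 cells for antagonist activity at histamine H2 receptor (Homo sapiens); a higher number here means a more potent compound, by a factor of ten per unit of this negative logarithm, a lower number a less potent compound:
compound 1 `N#C/N=C(\NCCCCc1ccccc1)NCCCCc1c[nH]cn1` gives 5.03
compound 2 `N#C/N=C(/NCCCCc1c[nH]cn1)NCCCc1ccccn1` gives 5.48
compound 3 `N#C/N=C(/NCCCCc1c[nH]cn1)NCCCc1cccnc1` gives 5.92

Compound 3 stands highest of the three, with compound 2 nearest (a number 0.44 log units higher from compound 2 to compound 3 (beyond the scatter)) and compound 1 furthest (a number 0.89 log units higher from compound 1 to compound 3 (beyond the scatter)). Compound 4 `CN/C(=N\C#N)NCCCCc1c[nH]cn1` differs from compound 3 by hydrogen in place of 2-(pyridin-3-yl)ethyl on a saturated chain carbon bound to an amine nitrogen. Going by the values given here, none of the measured steps, a number 0.45 log units higher from compound 1 to compound 2 (beyond the scatter), a number 0.89 log units higher from compound 1 to compound 3 (beyond the scatter) and a number 0.44 log units higher from compound 2 to compound 3 (beyond the scatter), removes this group; they only exchange the aromatic ring at the chain end, and all three rings gave values above the shortened compound 4 has to start from. The data give no direct guide for deleting the chain, so a loss in this assay is expected. Compound 4 is estimated at 4.5 (range 3.8 to 5.2), a step of a number 1.42 log units lower from compound 3 to compound 4 (beyond the scatter).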

Compound 4, negative logarithm of the antagonist equilibrium constant: < 5
Compound 4: no number, only a limit; the forecaster's own chance of this, stated with the estimate: 25%; the middle value does not contradict the limit.
By their numbers in this assay, from the lowest: compound 1; then compound 2; then compound 3. At a limit, below all of these: compound 4.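

In this assay compound 4 gives only a limit, < 5. Hydrogen in place of the chain end costs potency, with a number at least 0.92 log units lower from compound 3 to compound 4 (beyond the scatter) and a number at least 0.48 log units lower from compound 2 to compound 4 (beyond the scatter), so the group matters as a whole, which the earlier ring exchanges could not show. The step between compound 1 and compound 4 cannot be read against this limit. As far as these compounds go, how deep the loss goes stays open: the limit of < 5 in this assay, at which 1 of the 4 values shown sits. Also open, from the compounds shown here alone, is whether an ethyl chain without a ring, or a terminal amine or carboxylic acid, would retain any of the potency of compound 3.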